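Thiourea to urea swap on the catechol-bearing sulfonamide core

A few compounds are considered here, and "the series" means these few. Any claim that something is new, unique, unknown or untested is made for them only; others in the source may bear on it.

Measured so far:
compound 1 `COc1ccc(NC(=S)NCCNS(=O)(=O)c2sccc2-c2ccc(C)cc2Oc2ccc(O)c(O)c2)cc1`: > 20000 nM
compound 2 `O=C(NCCNS(=O)(=O)c1ccc(-c2ccccc2O[C@H]2CC[C@@H](O)CC2)s1)Nc1cc(C(F)(F)F)cc(C(F)(F)F)c1`: 14100 nM

In a functional assay on HeLa cells (Homo sapiens) for inhibition, read by CCK-8 assay, with a stated time of 48 h (on this read-out lower numbers stand for stronger inhibition and higher numbers for weaker inhibition), compound 1 gives > 20000 nM, which is a limit of the assay and not a number. Compound 1 therefore stands at the limit of > 20000 nM in this assay, at which 1 of the 2 values shown sits. In this assay compound 2 gives 14100 nM. Going by the values given here, no step between the two measured compounds is defined, as they differ in more than one place.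

Compound 3 `COc1ccc(NC(=O)NCCNS(=O)(=O)c2sccc2-c2ccc(C)cc2Oc2ccc(O)c(O)c2)cc1` is not yet measured. It differs from compound 1 as follows: a group of 11 heavy atoms (8 carbon, 1 nitrogen, 2 oxygen; one six-membered aromatic ring of carbon only) in place of a group of 11 heavy atoms (8 carbon, 1 nitrogen, 1 oxygen, 1 sulfur; one six-membered aromatic ring of carbon only), on an amine nitrogen.

Both measured compounds sit at the weak end of what this assay resolves, and the shown change is a like-for-like replacement of one group by another of the same size. The step of a number no higher from compound 1 to compound 3 (the limit leaves the size open) is expected to lie within the scatter, with a fair chance that only a limit is reported again. Compound 3 is thus estimated at 20000 nM, with a range from 8000 nM to 50000 nM.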

Compound 3, half-maximal inhibitory concentration: > 20000 nM
Compound 3: only a limit was reported (the forecaster's own chance of this, stated with the estimate: 55%); the middle value lies on the limit itself.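

In this assay compound 1 and compound 3 both stand only as limits of the assay and not as numbers, so no step between them can be read: the limit of > 20000 nM in this assay, at which 2 of the 3 values shown sit.

The compounds shown leave open whether the (4-methoxyphenyl)carbamoyl group on the amine nitrogen differs in any way from the group it replaces.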